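Trading 2-methylphenyl for 4-chlorophenyl

The source may report more compounds than this note shows. Statements on the series, on what has been measured and on what is new or still open speak of the compounds shown alone.

Of the compounds shown here, three sharing one core have been measured in a functional assay on LoVo cells (Homo sapiens) for inhibition, read by MTT assay, with a stated time of 24 h; on this read-out lower numbers stand for stronger inhibition and higher numbers for weaker inhibition. Compound 1 `CC1(C)[C@H]2CC[C@]1(C)N(Cc1cn(-c3ccc(O)cc3)nn1)C(=O)C2`, which carries 4-hydroxyphenyl, gives 410 nM. Compound 2 `Cc1ccc(-n2cc(CN3C(=O)C[C@@H]4CC[C@@]3(C)C4(C)C)nn2)cc1`, which carries 4-methylphenyl, gives 50 nM. Compound 3 `Cc1ccccc1-n1cc(CN2C(=O)C[C@@H]3CC[C@@]2(C)C3(C)C)nn1`, which carries 2-methylphenyl, gives 80 nM, within the scatter of compound 2 and well under compound 1.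

Compound 4 `CC1(C)[C@H]2CC[C@]1(C)N(Cc1cn(-c3ccc(Cl)cc3)nn1)C(=O)C2` has 4-chlorophenyl in place of 2-methylphenyl on an aromatic nitrogen. Going by the values given here, no tested compound carries chlorine, so the evidence is indirect. Leaving the hydroxy-bearing group for a methyl-bearing one gave an 8.2-fold lower number from compound 1 to compound 2 (0.91 log units; beyond the scatter) and a 5.1-fold lower number from compound 1 to compound 3 (0.71 log units; beyond the scatter). Between the two methylphenyl groups, the data show only a 1.6-fold higher number from compound 2 to compound 3 (0.20 log units; within the scatter). Like compound 2, compound 4 has its substituent at the 4-position and no hydroxy group, so it is expected to fall near that pair. The estimated step is a 1.3-fold lower number from compound 3 to compound 4 (0.12 log units; within the scatter), which would not go beyond the scatter. Compound 4 is estimated at 60 nM, with an expected range from 20 nM to 200 nM.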

Compound 4, half-maximal inhibitory concentration: 160 nM
Beside the measured number, compound 4's estimate is 2.7-fold (0.43 log units) below it; the measured number falls inside the stated range.
By their numbers in this assay, from the lowest: compounds 2, 3 and 4 (each within the scatter of the next, the first and the last beyond it); then compound 1.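

Comparing 4-chlorophenyl with the other two groups of this kind shows that the loss of hydroxy is not the whole story: chloro in place of methyl gives a 3.2-fold higher number from compound 2 to compound 4 (0.51 log units; beyond the scatter) as a modest step, and chloro in place of hydroxy gives a 2.6-fold lower number from compound 1 to compound 4 (0.41 log units; beyond the scatter) as another, which puts compound 4 in the middle of that set. On this nitrogen, the change from 2-methylphenyl to 4-chlorophenyl gives a 2.0-fold higher number from compound 3 to compound 4 (0.30 log units; within the scatter) and so does not separate the two compounds, although both the substituent and its place on the phenyl ring differ. Nothing measured here explains these differences.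

As far as these compounds go, whether 2-chlorophenyl would match compound 3 remains open, as that group would test chlorine with the substituent placed as in 2-methylphenyl. How far the trend extends to groups such as 4-methoxyphenyl or 4-aminophenyl is also unknown.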